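The source may report more compounds than this note shows. Statements on the series, on what has been measured and on what is new or still open speak of the compounds shown alone.

For the measured compounds named here, compound 2 `Cc1cc(-c2ccccc2)n(/C(N)=N/S(=O)(=O)c2cc(C)c(Cl)cc2SCc2cccc(Cl)c2)n1` gives 25000 nM in a functional assay on MCF7 cells (Homo sapiens) for cytotoxicity, read by MTT assay, with a stated time of 72 h (on this read-out lower numbers stand for stronger inhibition and higher numbers for weaker inhibition), the lower of the two numbers measured so far. Going by the values given here, its only neighbour is compound 1 `Cc1cccc(CSc2cc(Cl)c(C)cc2S(=O)(=O)/N=C(\N)n2nc(C)cc2-c2ccccc2)c1`, which in this assay gives 105000 nM, and the step of a 4.2-fold lower number from compound 1 to compound 2 (0.62 log units; beyond the scatter) arose from a chloro in place of methyl on an aromatic carbon. Compound 3 `Cc1cc(-c2ccccc2)n(/C(N)=N/S(=O)(=O)c2cc(C)c(Cl)cc2SCc2ccccc2C(F)(F)F)n1` has not yet been measured in this assay. It differs from compound 2 in one place: 2-(trifluoromethyl)phenyl in place of 3-chlorophenyl on a saturated chain carbon bound to a sulfur. Among the compounds with values here, the one measured step bears on this change only in that it, too, altered the benzyl ring bound to the sulfur, and it was modest. Nothing measured tells how a 2-(trifluoromethyl)phenyl compares with a 3-chlorophenyl at that position, so the direction of any step is open. The expected step from compound 2 to compound 3 is therefore a 1.2-fold higher number from compound 2 to compound 3 (0.08 log units; within the scatter), that is, none clearly beyond the scatter. For compound 3 the estimate in this assay is 30000 nM, with a range from 8000 nM to 110000 nM.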

Compound 3, half-maximal inhibitory concentration: 101000 nM
Estimate against measurement, compound 3: 3.4-fold (0.53 log units) below; measured number inside the range.
By their numbers in this assay, from the lowest: compound 2; then compounds 3 and 1 (each within the scatter of the next).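

In this assay, the position on the saturated chain carbon bound to a sulfur now shows a second step beyond the scatter: with 2-(trifluoromethyl)phenyl in place of 3-chlorophenyl, there is a 4.0-fold higher number from compound 2 to compound 3 (0.61 log units; beyond the scatter), which takes back about as much as the chloro in place of methyl had gained. The other new step, a 1.0-fold lower number from compound 1 to compound 3 (0.02 log units; within the scatter), lies within the scatter, so 2-(trifluoromethyl)phenyl and 3-methylphenyl cannot be told apart at this position, and of the three groups only 3-chlorophenyl stands out, making compound 2 the strongest of the three compounds in this read-out. Nothing available explains why the 3-chlorophenyl group differs from the other two.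

The compounds shown change the group on the ring and its place on the ring together, so they leave open which of the two matters; a 2-chlorophenyl or a 3-(trifluoromethyl)phenyl group would separate them. They also leave open how this position responds to an unsubstituted phenyl, to a ring carrying an amine or a carboxylic acid, or to a longer chain in place of the single saturated carbon bound to the sulfur.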